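From methoxy to methyl at the limit of the assay

The source may hold more compounds than are shown below. What is called first, only, known or untested is meant among the compounds shown, and "the series" means these compounds.

Values in an ADME assay on HEK293 cells (Homo sapiens) for cytotoxicity, with a stated time of 72 h; a lower number here means that less compound is needed, a higher number that more compound is needed for the effect:
compound 1 `Cc1ccc(-c2nc3ccccc3s2)cc1NC(=O)c1cc([N+](=O)[O-])c(N2CCC(C(=O)O)CC2)cc1Cl`: > 25000 nM
compound 2 `COC(=O)C1CCN(c2cc(Cl)c(C(=O)Nc3cc(-c4nc5ccccc5s4)ccc3C)cc2[N+](=O)[O-])CC1`: > 25000 nM
compound 3 `COc1ccc(-c2nc3ccccc3s2)cc1NC(=O)c1cc([N+](=O)[O-])ccc1Cl`: > 25000 nM

Compound 3 stands at > 25000 nM, which is a limit and not a number. It has company, as the data show (the limit of > 25000 nM in this assay, at which 3 of the 3 values shown sit). Compound 4 `Cc1ccc(-c2nc3ccccc3s2)cc1NC(=O)c1cc([N+](=O)[O-])ccc1Cl` differs from it in one place: methyl in place of methoxy on an aromatic carbon. Among the measured compounds shown here, the only measured step is a step that the two limits leave unreadable from compound 1 to compound 2, a different change that gives no size to carry over. Compound 1 carries the same methyl and also stands at a limit, > 25000 nM. The step expected in this assay is therefore a step that the limit leaves unreadable from compound 3 to compound 4, with none expected beyond the scatter. For compound 4 the estimated value is 30000 nM, with an expected range from 12000 nM to 80000 nM.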

Compound 4, half-maximal effective concentration: > 14000 nM
Compound 4: no number, only a limit (the forecaster's own chance of this, stated with the estimate: 85%); the middle value does not contradict the limit.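

Compound 4, like compound 1, compound 2 and compound 3, gives only a limit in this assay, and the steps between them cannot be read. The compounds shown leave open whether methyl in place of methoxy changes the concentration needed at all.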